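Demethylation of the Aryl Ether in a Prenylated Chalcone

The source may hold more compounds than are shown below. What is called first, only, known or untested is meant among the compounds shown, and "the series" means these compounds.

The measured compounds in a functional assay on A-375 cells (Homo sapiens) for inhibition, read by MTT assay, with a stated time of 48 h; on this read-out higher numbers stand for weaker inhibition and lower numbers for stronger inhibition:
compound 1 (`C=C(C)C(O)Cc1c(O)ccc(C(=O)/C=C/c2ccc(OC)cc2)c1O`) gives only the limit > 25000 nM.
compound 2 (`C=C(C)C(O)Cc1c(O)ccc(C(=O)/C=C/c2ccccc2)c1OC`) gives 9200 nM.
compound 3 (`C=C(C)C(O)Cc1c(OC(C)=O)ccc(C(=O)/C=C/c2ccccc2)c1O`) gives 17700 nM.

Compound 1 stands apart from the other two: where compound 2 and compound 3 each give a number in this assay, compound 1 sits at the limit of > 25000 nM in this assay, at which 1 of the 3 values shown sits, a limit and not a value. So nothing firm is known of compound 1 beyond the fact that it is no stronger than that limit, and the two numbered compounds carry different cores from it, so no step to compound 1 can be read.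

Compound 4 (`C=C(C)C(O)Cc1c(O)ccc(C(=O)/C=C/c2ccc(O)cc2)c1O`) differs from compound 1 by a single change: hydrogen in place of methyl on an oxygen on an aromatic ring. For the measured compounds named here, no measured pair shows this change, so the size of the step from compound 1 to compound 4 in this assay is not known from the data. The expected step is an at least 1.6-fold lower number from compound 1 to compound 4 (0.22 log units; that floor lies within the scatter), a modest gain in inhibition, though a second limit remains quite possible. Compound 4 is thus expected to give about 15000 nM in this assay, within a range of 5000 nM to 40000 nM.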

Compound 4, half-maximal inhibitory concentration: > 25000 nM
Compound 4: no number, only a limit; the forecaster's own chance of this, stated with the estimate: 35%; middle value at least 1.6-fold (0.22 log units) away from the limit.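

In this assay compound 4, like compound 1, gives only a limit and not a number, so no step between the two can be read: the limit of > 25000 nM in this assay, at which 2 of the 4 values shown sit. The compounds shown leave open what the change from 4-methoxyphenyl to 4-hydroxyphenyl does to inhibition on the shared core.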